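This account rests on a few compounds, and the source may have more. Where it says the series, first, only, none or still open, it means among the compounds named here.

Values in a functional assay on MCF7 cells (Homo sapiens) for antiproliferative activity, read by MTT assay, with a stated time of 72 h; a higher number here means a weaker inhibitor, a lower number a stronger inhibitor:
Compound 1, `CCCSc1nc(N/N=C(\C)c2ccc(OC)cc2)c2nnn(Cc3ccccc3)c2n1`: > 64000 nM
Compound 2, `CCCSc1nc(N/N=C/c2cc(OC)c(OC)c(OC)c2)c2nnn(Cc3ccccc3)c2n1`: > 64000 nM
Compound 3, `CCCSc1nc(N/N=C/c2ccc([N+](=O)[O-])cc2)c2nnn(Cc3ccccc3)c2n1`: 11000 nM

The value of compound 1 is a limit of the assay, not a number. The value of compound 2 is likewise a limit, not a number. Two of the three values shown are the limit of > 64000 nM in this assay, at which 2 of the 3 values shown sit. Going by the values given here, compound 3 therefore stands alone as the only compound in this assay with a measured number, 11000 nM, and no step between two measured compounds can be read from the set, so the size of any single change in this assay is unknown here.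

Compound 4, `CCCSc1nc(N/N=C/c2ccc(Br)cc2)c2nnn(Cc3ccccc3)c2n1`, is the next compound to be measured. It differs from compound 3 only in bromo in place of nitro on an aromatic carbon. Nothing in the measured set shows what this change does, so the expectation rests on compound 3 alone: the step from compound 3 to compound 4 in this assay is expected to be small or none beyond the scatter, with some chance that compound 4 reaches the limit as compounds 1 and 2 did. The estimated step is a 2.3-fold higher number from compound 3 to compound 4 (0.36 log units; beyond the scatter). Compound 4 is expected to give about 25000 nM in this assay, within a range of 7000 nM to 64000 nM.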

Compound 4, half-maximal inhibitory concentration: > 64000 nM
Compound 4 ended at the assay's limit (the forecaster's own chance of this, stated with the estimate: 35%); at least 2.5-fold (0.40 log units) between middle value and limit.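

In this assay, going by these compounds alone, bromo in place of nitro on an aromatic carbon, para to a large group, gives an at least 5.8-fold higher number from compound 3 to compound 4 (0.76 log units; beyond the scatter), the first single-place step that can be read. This position is therefore not indifferent to the group it carries: with the rest of the molecule unchanged, the 4-nitrophenyl compound keeps a measured number, while the 4-bromophenyl compound does not. The measured activity in this set now rests on compound 3 alone, and compound 4 joins compounds 1 and 2 at the limit: the limit of > 64000 nM in this assay, at which 3 of the 4 values shown sit.

From the compounds shown here alone, compound 4 carries a limit and not a number, so the full size of the step remains unknown, and no steps can be read among the compounds at the limit. Going by these compounds, it remains open whether nitro itself is needed at this position or whether another group, such as a nitrile, an amine or a carboxylic acid, would also give a measured number on the same core.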